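This account rests on a few compounds, and the source may have more. Where it says the series, first, only, none or still open, it means among the compounds named here.

Measured in a functional assay on MCF7 cells (Homo sapiens) for cytotoxicity, read by MTT assay, with a stated time of 48 h; on this read-out lower numbers stand for stronger inhibition and higher numbers for weaker inhibition:
- compound 1 `COc1ccc(-c2nc3ccccn3c2C(=O)/C=C\Nc2cc(OC)cc(OC)c2)cc1`: 14900 nM
- compound 2 `O=C(/C=C\Nc1cnc2ccccc2c1)c1c(-c2ccccc2)nc2ccccn12`: 5170 nM
- compound 3 `COc1cc(N/C=C\C(=O)c2c(-c3ccc(Cl)cc3)nc3ccccn23)cc(OC)c1OC`: 3390 nM

The number for compound 2 lies within the usual scatter of compound 3 and is clearly lower than that of compound 1. Compound 4 `O=C(/C=C\Nc1cnc2ccccc2c1)c1c(-c2ccc(Cl)cc2)nc2ccccn12` differs from compound 2 in one place: chloro in place of hydrogen on an aromatic carbon, which is chloro in place of hydrogen on an aromatic carbon, turning phenyl into 4-chlorophenyl. Within the data shown here, no measured pair shows this change alone. Compound 3, at 3390 nM, also carries 4-chlorophenyl but differs elsewhere too, so it is only a weak hint. In this assay, a small move toward a lower number is expected, within the scatter. The expected change is a 1.4-fold lower number from compound 2 to compound 4 (0.13 log units; within the scatter). For compound 4, the estimated value is 3800 nM, with an expected range of 1500 nM to 9500 nM.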

Compound 4, half-maximal inhibitory concentration: 18900 nM
Beside the measured number, compound 4's estimate is 5.0-fold (0.70 log units) below it; the measured number lies above the stated range.
By their numbers in this assay, from the lowest: compounds 3 and 2 (each within the scatter of the next); then compounds 1 and 4 (each within the scatter of the next).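

Turning phenyl into 4-chlorophenyl gives a 3.7-fold higher number from compound 2 to compound 4 (0.56 log units; beyond the scatter) in this assay, which means weaker inhibition. Among these compounds, this pair is the first to show this change alone, so the loss can be tied to this one place, an aromatic carbon para to a large group. No measurement at hand explains the loss. As far as these compounds go, whether fluoro, methyl or an amine at the same carbon would also raise the number remains open. So does whether chloro would shift the number by a similar amount with a different group on the other end of the molecule.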